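The source may hold more compounds than are shown below. What is called first, only, known or untested is meant among the compounds shown, and "the series" means these compounds.

Measured in an ADME assay on a cell-free system (plasma, Homo sapiens) for metabolic stability, with Plasma (Rattus norvegicus) as the target, read by HPLC, at pH 7.4; on this read-out lower numbers stand for a shorter-lived compound and higher numbers for a longer-lived compound:
compound 1 `CC(=O)Oc1ccccc1C(=O)O[C@H]1CO[C@H]2[C@@H]1OC[C@H]2OC(=O)c1ccnn1C` gives 0.0642 h
compound 2 `COc1cccc(C(=O)O[C@@H]2CO[C@H]3[C@@H]2OC[C@@H]3OC(=O)c2ccccc2OC(C)=O)c1` gives 0.0142 h
compound 3 `CC(=O)Oc1ccccc1C(=O)O[C@H]1CO[C@H]2[C@@H]1OC[C@H]2OC(=O)c1ccc([N+](=O)[O-])cc1` gives 0.0227 h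

Compound 3 stands between the other two in this assay: the step of a 2.8-fold lower number from compound 1 to compound 3 (0.45 log units; beyond the scatter) is beyond the scatter, whereas the step of a 1.6-fold higher number from compound 2 to compound 3 (0.20 log units; within the scatter) is within it, so compound 3 and compound 2 are not separated. All three share the core of compound 3 and differ only in the group on one carbonyl carbon.

Compound 4 `CC(=O)Oc1ccccc1C(=O)O[C@H]1CO[C@H]2[C@@H]1OC[C@H]2OC(=O)c1ccc(CO[N+](=O)[O-])cc1` is not yet measured. It differs from compound 3 by (nitrooxy)methyl in place of nitro on an aromatic carbon. Among the compounds with values here, none of the measured steps varies a substituent on an aromatic ring while keeping that ring; each exchanges the whole group on the carbonyl carbon: a 4.5-fold lower number from compound 1 to compound 2 (0.66 log units; beyond the scatter), a 2.8-fold lower number from compound 1 to compound 3 (0.45 log units; beyond the scatter), a 1.6-fold higher number from compound 2 to compound 3 (0.20 log units; within the scatter). The two steps between aromatic six-membered groups stay within the scatter, and the whole series covers a narrow span. Within the data shown here, no step bears directly on the change, so a step of no size beyond the scatter is expected, a 1.1-fold higher number from compound 3 to compound 4 (0.04 log units; within the scatter). Compound 4 is estimated at 0.025 h, with a range from 0.01 h to 0.06 h.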

Compound 4, half-life: 0.04 h
Estimate against measurement, compound 4: 1.6-fold (0.20 log units) below; measured number inside the range.
By their numbers in this assay, from the lowest: compounds 2, 3, 4 and 1 (each within the scatter of the next, the first and the last beyond it).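

In this assay, the exchange of nitro for (nitrooxy)methyl on this aromatic carbon, the only change shown that keeps the ring, gives a 1.8-fold higher number from compound 3 to compound 4 (0.25 log units; within the scatter), so the two groups are not separated at this position. The change does alter how the compound reads against the other groups on the carbonyl carbon: a 2.8-fold higher number from compound 2 to compound 4 (0.45 log units; beyond the scatter), while a 1.6-fold lower number from compound 1 to compound 4 (0.21 log units; within the scatter), the reverse of compound 3, which is separated from compound 1 and not from compound 2. Nothing available explains these differences in half-life.

Still open, on these data alone, is whether an amine, a carboxylic acid or a longer chain ending in nitrooxy on the same aromatic carbon would also stay within the scatter of compound 3. The compounds shown also leave open whether (nitrooxy)methyl would give a similar step on the 3-methoxyphenyl or 1-methyl-1H-pyrazol-5-yl groups.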